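Swapping an ether link for an amine link on the core

A few compounds are considered here, and "the series" means these few. Any claim that something is new, unique, unknown or untested is made for them only; others in the source may bear on it.

Measured compounds:
- compound 1 `COc1cccc(Oc2ccc3cc(NC(=O)c4ccc(OC(C)=O)c(CC=C(C)C)c4)c(=O)oc3c2C)c1`: 15700 nM
- compound 2 `COc1cccc(Oc2ccc3cc(NC(=O)c4ccc(O)c(CC=C(C)C)c4)c(=O)oc3c2C)c1`: 62800 nM
- compound 3 `COc1ccc(Oc2ccc3cc(NC(=O)c4ccc(OC)c(-c5cccc(OC)c5)c4)c(=O)oc3c2C)cc1`: > 100000 nM

In a functional assay on MCF7 cells (Homo sapiens) for antiproliferative activity (on this read-out lower numbers stand for stronger inhibition and higher numbers for weaker inhibition), compound 1 gives the lowest of the two numbers shown. Compound 2 differs from it in a single place, hydrogen in place of acetyl on an oxygen on an aromatic ring, and that change gave a 4.0-fold higher number from compound 1 to compound 2 (0.60 log units; beyond the scatter). For compound 3 only a limit of the assay is known, (the limit of > 100000 nM in this assay, at which 1 of the 3 values shown sits), so it cannot be ranked against the others.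

Compound 4 `COc1ccc(Nc2ccc3cc(NC(=O)c4ccc(OC(C)=O)c(CC=C(C)C)c4)c(=O)oc3c2C)cc1` has not yet been measured in this assay. It differs from compound 1 as follows: (4-methoxyphenyl)amino in place of 3-methoxyphenoxy on an aromatic carbon. The change sits on an aromatic carbon of a six-membered aromatic ring of carbon only, part of a fused or bridged system of two rings, ortho to a methyl group, meta and para to a fused ring.

Within the data shown here, none of the measured steps touches this position: the one measured step changes the acetyl group elsewhere, and compound 3 differs from compound 1 in several places at once. The data therefore give no direct guide to the size or direction of the step, and no step beyond the scatter is assumed. Compound 4 is expected to give about 15000 nM, within 5000 nM to 50000 nM, which means an expected step of a 1.0-fold lower number from compound 1 to compound 4 (0.02 log units; within the scatter).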

Compound 4, half-maximal inhibitory concentration: > 100000 nM
Compound 4 was reported as a limit; the forecaster's own chance of this, stated with the estimate: 10%; middle value at least 6.6-fold (0.82 log units) away from the limit.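

Among these compounds, this result gives the first measured step at this aromatic carbon, ortho to a methyl group, since the only earlier step in this assay lay on the acetyl group elsewhere in the molecule: an at least 6.3-fold higher number from compound 1 to compound 4 (0.80 log units; beyond the scatter). The position is therefore not indifferent to what it carries, even though the group that leaves and the group that enters have the same number of heavy atoms and each holds one six-membered aromatic ring of carbon only. For compound 4 only a limit of the assay is known, not a number, so the true size of the step remains unknown: the limit of > 100000 nM in this assay, at which 2 of the 4 values shown sit.

The change also does two things at once: it replaces the oxygen link with an amine link that brings a hydrogen-bond donor, and it moves the methoxy group from the 3-position to the 4-position of the outer ring, so the compounds shown cannot say which of these matters. A (3-methoxyphenyl)amino group on the core of compound 1 would separate the two, and a much smaller group here, such as a plain methoxy or a chlorine, would show whether the outer ring is needed at all.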